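Compound 3 to compound 4: an expected fall in solubility

The source may hold more compounds than are shown below. What is called first, only, known or untested is meant among the compounds shown, and "the series" means these compounds.

Measured so far in a physicochemical assay for solubility, read by LC-MS, in phosphate buffer, with a stated time of 24 h, at pH 7.4; a lower number here means a less soluble compound, a higher number a more soluble compound:
compound 1 `Cn1cc(-c2cnc(NCc3c(F)ccc4c3CCO4)c3cn[nH]c(=O)c23)cn1`: 1000 nM
compound 2 `Cc1nc(CO)ccc1-c1cnc(NCc2c(F)ccc3c2CCO3)c2cn[nH]c(=O)c12`: 3000 nM
compound 3 `Cc1nc(CN(C)C)ccc1-c1cnc(NCc2c(F)ccc3c2CCO3)c2cn[nH]c(=O)c12`: > 1000000 nM

Compound 3 stands highest of the three, at > 1000000 nM, a limit of the assay and not a number. Compound 4 `CNC(=O)c1cc(-c2cnc(NCc3c(F)ccc4c3CCO4)c3cn[nH]c(=O)c23)n(C)n1` carries 1-methyl-3-(methylcarbamoyl)-1H-pyrazol-5-yl in place of 6-((dimethylamino)methyl)-2-methylpyridin-3-yl on an aromatic carbon. Two measured steps were large: an at least 1000-fold higher number from compound 1 to compound 3 (3.00 log units; beyond the scatter) and an at least 330-fold higher number from compound 2 to compound 3 (2.52 log units; beyond the scatter). The third, a 3.0-fold higher number from compound 1 to compound 2 (0.48 log units; beyond the scatter), was modest. Compound 4 has no dimethylamino group, and like compound 1 it has a five-membered aromatic ring, so a large fall is expected in this assay. The estimated step is an at least 330-fold lower number from compound 3 to compound 4 (2.52 log units; beyond the scatter). The expected value for compound 4 is 3000 nM, estimated to lie between 500 nM and 20000 nM.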

Compound 4, solubility: 7000 nM
Estimate against measurement, compound 4: 2.3-fold (0.37 log units) below; the range from low to high includes it.
By their numbers in this assay, from the lowest: compound 1; then compound 2; then compound 4. At a limit, above all of these: compound 3.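

In this assay, 1-methyl-3-(methylcarbamoyl)-1H-pyrazol-5-yl at this position gives a 7.0-fold higher number from compound 1 to compound 4 (0.85 log units; beyond the scatter) and a 2.3-fold higher number from compound 2 to compound 4 (0.37 log units; beyond the scatter), so a modest rise is possible here with no dimethylamino group present. Losing 6-((dimethylamino)methyl)-2-methylpyridin-3-yl still gives an at least 140-fold lower number from compound 3 to compound 4 (2.15 log units; beyond the scatter), so the large gain stays with compound 3 alone. That step rests on a limit for compound 3, not a number: the limit of > 1000000 nM in this assay, at which 1 of the 4 values shown sits. The compounds shown leave open whether a dimethylamino or other amine on the five-membered ring would reach that limit. They also do not separate the methylcarbamoyl group from the ring that carries it.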